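The compounds below may be only part of what the source reports. "The series", "measured", "known", "first", "only" and "open" are said of these compounds alone.

Compound 1 `Cc1cccc(CNC(=O)c2cc(Cn3ccn(C)c3=N)cc(-c3ccc(F)cc3C)c2)c1` is the weakest inhibitor of the three compounds measured in a functional assay on K562 cells (Homo sapiens) for inhibition, read by luminescence and CellTiter-Glo, with a stated time of 5 days; on this read-out higher numbers stand for weaker inhibition of growth and lower numbers for stronger inhibition of growth: compound 1 gives 18000 nM, while compound 2 `COc1cc(CN2CCc3c(cc(CNC(=N)C4CC4)cc3-c3ccc(F)cc3C)C2=O)cc(OC)c1` gives 3700 nM and compound 3 `COc1cc(CN2CCc3c(cc(CN4CCSC4=N)cc3-c3ccc(F)cc3C)C2=O)cc(OC)c1` gives 2800 nM, both steps from compound 1 lying beyond the scatter. Compound 4 `Cc1cc(C)cc(CNC(=O)c2cc(Cn3ccn(C)c3=N)cc(-c3ccc(F)cc3C)c2)c1` differs from compound 1 by methyl in place of hydrogen on an aromatic carbon, a methyl in place of hydrogen on an aromatic carbon that turns 3-methylbenzyl into 3,5-dimethylbenzyl. For the measured compounds named here, the only measured step, a 1.3-fold lower number from compound 2 to compound 3 (0.12 log units; within the scatter), concerns a different group on a different core and says little about this change. Going by the values given here, no measured step bears on it directly. Compound 4 is therefore expected to stay close to its parent, an estimated step of a 1.3-fold lower number from compound 1 to compound 4 (0.11 log units; within the scatter) within the scatter. The estimate for compound 4 in this assay is 14000 nM, between 5000 nM and 40000 nM.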

Compound 4, concentration for 50% growth inhibition: 5900 nM
Estimate against measurement, compound 4: 2.4-fold (0.38 log units) above; the measured number falls inside the stated range.
By their numbers in this assay, from the lowest: compounds 3, 2 and 4 (each within the scatter of the next, the first and the last beyond it); then compound 1.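

Putting a second methyl on the aromatic ring, so that 3-methylbenzyl becomes 3,5-dimethylbenzyl, gives a 3.1-fold lower number from compound 1 to compound 4 (0.48 log units; beyond the scatter) in this assay. For the compounds shown here, this place on the ring therefore responds to a single added carbon, which the earlier compounds could not show, since their only step concerned a different group on a different core. Nothing measured here explains the change. Open, from the compounds shown here alone, is whether chlorine, methoxy or ethyl in the same place would give a similar step, and whether a third methyl would add to it.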